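The source may hold more compounds than are shown below. What is called first, only, known or untested is meant among the compounds shown, and "the series" means these compounds.

Measured so far:
- compound 1, `Nc1ncnc2c1nc(O)n2Cc1ccc(F)cc1`: 10 uM
- compound 2, `Nc1ncnc2c1nc(I)n2Cc1ccccc1`: > 10 uM
- compound 3, `CNc1nc(N)c2nc(O)n(Cc3ccccc3)c2n1`: 1 uM

Of the compounds shown here, three sharing one core have been tested in a functional assay (spleen, spleen) for activation, with Mus musculus as the target; a higher number here means that more compound is needed for the effect, a lower number that less compound is needed. Compound 1 gives 10 uM in this assay. For compound 2 the result is only a limit of the assay, > 10 uM, so no number is known for it; the same is true of the limit of > 10 uM in this assay, at which 1 of the 3 values shown sits. Compound 3 gives 1 uM, the lowest of the two numbers obtained, and its gap to compound 1 lies beyond the usual scatter.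

Compound 4, `COc1nc(N)c2nc(O)n(Cc3ccccc3)c2n1`, has not yet been measured in this assay. It differs from compound 3 in one place: methoxy in place of methylamino on an aromatic carbon. Among the compounds with values here, no two measured compounds differ by such a change, so there is no measured step of this kind to lean on. A hydrogen-bond donor is lost in the exchange, nothing more can be said of it here.

The expectation is a step from compound 3 to compound 4 of a 2.0-fold higher number from compound 3 to compound 4 (0.30 log units; within the scatter), that is, a slight loss, close to the scatter. Compound 4 is therefore estimated at 2 uM, within a range from 0.5 uM to 10 uM.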

Compound 4, minimum effective concentration: 0.1 uM
Compound 4: the middle estimate sits 20-fold (1.30 log units) above what was measured; the measured number lies below the stated range.
By their numbers in this assay, from the lowest: compound 4; then compound 3; then compound 1.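

Within the data shown here, exchanging methylamino for methoxy at this place, on the aromatic carbon between two ring nitrogen atoms, gives a 10-fold lower number from compound 3 to compound 4 (1.00 log units; beyond the scatter) in this assay, the first single-place comparison. It shows that the group at this position can change how much compound is needed, and that the hydrogen-bond donor of methylamino is not required for the effect, as methoxy has none and compound 4 still needs less compound than compound 3. Nothing measured here explains why the step runs in this direction.

One pair cannot show whether the gain belongs to methoxy alone or would extend to other groups at this place, such as ethoxy, a longer butoxy chain or a simple amine. It also leaves open whether the same exchange would give a similar step on a different group at the ring nitrogen.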